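The source may report more compounds than this note shows. Statements on the series, on what has been measured and on what is new or still open speak of the compounds shown alone.

Measured compounds:
compound 1, `COc1cc(C=C(C(=O)/C=C/c2cccc(OC)c2OC)C(=O)/C=C/c2cccc(OC)c2OC)cc(Br)c1O`, 240 nM
compound 2, `COc1cc(C=C(C(=O)/C=C/c2cccc(OC)c2OC)C(=O)/C=C/c2cccc(OC)c2OC)cc(OC)c1O`, 210 nM
compound 3, `COc1cc(OC)c(/C=C/C(=O)C(=Cc2cc(Br)c(O)c(OC)c2)C(=O)/C=C/c2c(OC)cc(OC)cc2OC)c(OC)c1`, 660 nM

All three were tested in a functional assay on HepG2 cells (Homo sapiens) for antiproliferative activity, read by sulforhodamine B assay, with a stated time of 48 h; on this read-out higher numbers stand for weaker inhibition and lower numbers for stronger inhibition. Compound 1 gives 240 nM there, compound 2 gives 210 nM, and compound 3 gives 660 nM. Compounds 1 and 2 differ in one place, (methoxy in place of bromo on an aromatic carbon), and this change produced a 1.1-fold lower number from compound 1 to compound 2 (0.06 log units; within the scatter). Compound 3 carries a different core from compound 1; the difference between the two cores is not broken down here, but compound 3 stands at the highest number of the three.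

Compound 4, `COc1cc(OC)c(/C=C/C(=O)C(=Cc2cc(OC)c(O)c(OC)c2)C(=O)/C=C/c2c(OC)cc(OC)cc2OC)c(OC)c1`, is not yet measured. It relates to compound 3 by the same change, (methoxy in place of bromo on an aromatic carbon). Going by the values given here, since the only earlier example of this change gave a 1.1-fold lower number from compound 1 to compound 2 (0.06 log units; within the scatter), compound 4 is expected to sit close to compound 3, with a step of about a 1.1-fold lower number from compound 3 to compound 4 (0.04 log units; within the scatter) expected in this assay. On that basis compound 4 is estimated at 600 nM, within a range from 300 nM to 1300 nM.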

Compound 4, half-maximal inhibitory concentration: 510 nM
For compound 4 the middle estimate is 1.2-fold (0.07 log units) above the measured one; the range from low to high includes it.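

In this assay, the exchange of bromo for methoxy, which turns 3-bromo-4-hydroxy-5-methoxyphenyl into 4-hydroxy-3,5-dimethoxyphenyl, gave a 1.3-fold lower number from compound 3 to compound 4 (0.11 log units; within the scatter) on the core of compound 3. Set beside the earlier case, the change carried over from the core of compound 1 to the core of compound 3 with no difference in size that the data can separate: the same change on two cores in this assay, a 1.1-fold lower number (0.06 log units; within the scatter) from compound 1 to compound 2 and a 1.3-fold lower number (0.11 log units; within the scatter) from compound 3 to compound 4, 1.1-fold (0.05 log units) apart, within the scatter of two such steps. This shows that on these two cores methoxy and bromo could be exchanged at this place with the number staying within the scatter, but two pairs do not show that the same would hold on a further core, and they say nothing of what either group does in the cells.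

The compounds shown carry only bromo or methoxy at this place, so it stays open how a chloro group, an amine or a longer alkoxy chain there would read in this assay. Also open, from the compounds shown here alone, is what would follow if a carboxylic acid took the place of the hydroxy group.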